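A few compounds are considered here, and "the series" means these few. Any claim that something is new, unique, unknown or untested is made for them only; others in the source may bear on it.

Among the compounds with values here, in an assay on cells for displacement of a labelled ligand from Neuronal acetylcholine receptor; alpha3/beta4 (Homo sapiens) (on this read-out lower numbers stand for stronger inhibition and higher numbers for weaker inhibition), compound 2 `O=C(Nc1ccc(Cl)cc1)c1cncc(N2CC3CC(C2)N3)c1` gives 123 nM, the highest of the two numbers known; compound 1 `O=C(Nc1ccc(I)cc1)c1cncc(N2CC3CC(C2)N3)c1` gives 103 nM, and the step of a 1.2-fold higher number from compound 1 to compound 2 (0.08 log units; within the scatter) lies within the scatter. Compound 3 `CCc1cccc(NC(=O)c2cncc(N3CC4CC(C3)N4)c2)c1` differs from compound 2 in that (3-ethylphenyl in place of 4-chlorophenyl on an amide-type nitrogen). Within the data shown here, the only measured step concerns chloro in place of iodo and does not touch this change, so it bears on it only loosely. One therefore expects no step beyond the scatter for compound 3 in this assay, with the estimate 200 nM, between 70 nM and 600 nM. That estimate means a step of a 1.6-fold higher number from compound 2 to compound 3 (0.21 log units; within the scatter) from compound 2 to compound 3.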

Compound 3, inhibition constant: 306 nM
Compound 3: middle estimate off by 1.5-fold (0.18 log units), on the low side, within the range that was stated.
By their numbers in this assay, from the lowest: compounds 1 and 2 (each within the scatter of the next); then compound 3.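

In this assay, exchanging the whole aryl group on the amide-type nitrogen moves the number beyond the scatter, which the exchange of one halogen for another did not do. Placing 3-ethylphenyl in place of 4-chlorophenyl gives a 2.5-fold higher number from compound 2 to compound 3 (0.40 log units; beyond the scatter) and placing it in place of 4-iodophenyl gives a 3.0-fold higher number from compound 1 to compound 3 (0.47 log units; beyond the scatter), both modest steps towards weaker inhibition. No measurement at hand explains these steps.

The compounds shown do not separate the effect of the ethyl group from that of its ring position. Going by these compounds, how a 4-ethylphenyl, 3-chlorophenyl or 3-aminophenyl group would read remains open.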